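Series notes: ring chloro added to compound 2

This account rests on a few compounds, and the source may have more. Where it says the series, first, only, none or still open, it means among the compounds named here.

Measured compounds in an ADME assay on Vero cells (Chlorocebus sabaeus) for cytotoxicity; on this read-out higher numbers stand for lower toxicity in this test and lower numbers for higher toxicity in this test:
Compound 1 `Fc1ccc(-c2nn3ccc(Cl)cc3c2-c2ccnc(NC3CCCC3)n2)cc1` sits at the limit of > 40000 nM in this assay.
Compound 2 `Fc1ccc(-c2nn3ccc(NC4CCCC4)cc3c2-c2ccnc(NC3CCCC3)n2)cc1` gives 18000 nM in this assay.
Compound 3 `c1cc(-c2c(-c3ccc(OCC4CC4)cc3)nn3ccc(NC4CCCC4)cc23)nc(NC2CCCC2)n1` sits at the limit of > 40000 nM in this assay.

Among the measured compounds shown here, compound 2 holds the only number among the three results; the other two results are limits, as noted in the limit of > 40000 nM in this assay, at which 2 of the 3 values shown sit. For the measured compounds named here, the step of an at least 2.2-fold lower number from compound 1 to compound 2 (0.34 log units; beyond the scatter) and the step of an at least 2.2-fold higher number from compound 2 to compound 3 (0.34 log units; beyond the scatter) are the only measured steps, and neither involves the change now in question.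

Compound 4 `Fc1ccc(-c2nn3c(Cl)cc(NC4CCCC4)cc3c2-c2ccnc(NC3CCCC3)n2)cc1` differs from compound 2 by chloro in place of hydrogen on an aromatic carbon. Going by the values given here, no measured pair in this set swaps hydrogen for chloro, so nothing here bears directly on the step. The two measured steps were each at least modest, which sets the scale of change seen so far. For compound 4 the expectation is a step of no change at the digits printed from compound 2 to compound 4 (within the scatter), that is, no change beyond the scatter. The estimate for compound 4 in this assay is 18000 nM, with a range from 8000 nM to 40000 nM.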

Compound 4, half-maximal cytotoxic concentration: > 40000 nM
Compound 4: no number, only a limit; the forecaster's own chance of this, stated with the estimate: 25%; middle value at least 2.2-fold (0.34 log units) from the limit.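

In this assay, among the compounds shown here, chloro in place of hydrogen next to the ring nitrogen gives the first reading for this position and this change: an at least 2.2-fold higher number from compound 2 to compound 4 (0.34 log units; beyond the scatter). Compound 4 sits at a limit, > 40000 nM, and this is not a number, so the step has a floor but no measured size. Each of the three compounds that differ from compound 2 in one place, at three different sites, now reads at that limit, which leaves compound 2 as the only compound with a number: the limit of > 40000 nM in this assay, at which 3 of the 4 values shown sit.

As far as these compounds go, how far compound 4 lies past the limit stays unknown, so its step cannot be ranked against the two earlier steps. Also open, from the compounds shown here alone, is whether a methyl group, a methoxy group or an amine at this position would move the read-out as chloro does.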